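Compound 4 and a shared limit on stability

This account rests on a few compounds, and the source may have more. Where it says the series, first, only, none or still open, it means among the compounds named here.

Measured so far in an ADME assay on microsomes from liver (Canis lupus familiaris) for metabolic stability; a lower number here means that the compound disappears faster, a higher number that the compound lasts longer
Compound 1 (`Nc1nc(NCCNc2ncc(-c3ncc[nH]3)c(-c3ccc(F)cc3Br)n2)ccc1[N+](=O)[O-]`) gives > 0.5 h as a limit
Compound 2 (`Nc1nc(NCCNc2ncc(-c3ncc[nH]3)c(-c3ccc(F)cc3C(F)(F)F)n2)ccc1[N+](=O)[O-]`) gives > 0.5 h as a limit
Compound 3 (`Nc1nc(NCCNc2ncc(-c3ncc[nH]3)c(-c3ccc(Br)cc3Cl)n2)ccc1[N+](=O)[O-]`) gives > 0.5 h as a limit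

Compound 3 has no number, only its limit (> 0.5 h) in the record. That is the limit of > 0.5 h in this assay, at which 3 of the 3 values shown sit, and so the three compounds cannot be ranked. Compound 4 (`COc1cc(Cl)ccc1-c1nc(NCCNc2ccc([N+](=O)[O-])c(N)n2)ncc1-c1ncc[nH]1`) carries 4-chloro-2-methoxyphenyl in place of 4-bromo-2-chlorophenyl on an aromatic carbon with the shared core unchanged. The measured steps that bear on this change alter the same group, yet they are only a step that the two limits leave unreadable from compound 1 to compound 3 and a step that the two limits leave unreadable from compound 2 to compound 3 and a step that the two limits leave unreadable from compound 1 to compound 2 and so offer neither size nor direction. No step beyond the scatter is therefore expected, and the estimated move is a step that the limit leaves unreadable from compound 3 to compound 4 with no direction claimed. In this assay compound 4 is estimated at 0.7 h with an expected range from 0.35 h to 1.5 h and another report as a limit is likely.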

Compound 4, half-life: > 0.5 h
Compound 4 gave a limit, no number; the forecaster's own chance of this, stated with the estimate: 70%; the middle value does not contradict the limit.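

In this assay compound 4 gives > 0.5 h, a limit and not a number, so its steps from compound 1, compound 2 and compound 3 cannot be read: the limit of > 0.5 h in this assay, at which 4 of the 4 values shown sit. The compounds shown leave open what the actual half-life of each compound is and whether these group changes alter it at all.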